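Amide variation on the sulfonylpiperidine series

The source may hold more compounds than are shown below. What is called first, only, known or untested is meant among the compounds shown, and "the series" means these compounds.

In a functional assay on BXPC-3 cells (Homo sapiens) for inhibition, read by MTT assay, with a stated time of 7 days (on this read-out lower numbers stand for stronger inhibition and higher numbers for weaker inhibition), compound 1 `CCN(CC)S(=O)(=O)c1ccc(S(=O)(=O)N2CCC[C@@H](C(=O)N[C@H]3CCOC3)C2)cc1` gives 5270 nM. Compound 2 `CCN(CC)S(=O)(=O)c1ccc(S(=O)(=O)N2CCC[C@@H](C(=O)N3CCS(=O)(=O)CC3)C2)cc1` gives 4430 nM in this assay, the lowest of the two numbers shown, with the change a 1.2-fold lower number from compound 1 to compound 2 (0.08 log units; within the scatter) as the only measured step. Compound 3 `CCN(CC)S(=O)(=O)c1ccc(S(=O)(=O)N2CCC[C@@H](C(=O)N3CC[C@H](OC)C3)C2)cc1` differs from compound 2 by 3-methoxypyrrolidin-1-yl in place of 1,1-dioxothiomorpholin-4-yl on a carbonyl carbon. Among the compounds with values here, only that one step bears on this amide position, and it stayed within the scatter, so no step beyond the scatter is expected for compound 3 in this assay, a shift of a 1.0-fold higher number from compound 2 to compound 3 (0.01 log units; within the scatter). Compound 3 is therefore estimated at 4500 nM, within the range 2000 nM to 10000 nM.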

Compound 3, half-maximal inhibitory concentration: 6750 nM
For compound 3 the middle estimate is 1.5-fold (0.18 log units) below the measured one; the range from low to high includes it.
By their numbers in this assay, from the lowest: compounds 2, 1 and 3 (each within the scatter of the next).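

The change to 3-methoxypyrrolidin-1-yl on a carbonyl carbon gives a 1.5-fold higher number from compound 2 to compound 3 (0.18 log units; within the scatter) and a 1.3-fold higher number from compound 1 to compound 3 (0.11 log units; within the scatter) in this assay. This third amide, with a five-membered ring and a defined stereocentre, extends the within-scatter result at this position to all three compounds, which cannot be told apart in this read-out. No measurement shown accounts for this result. The compounds shown leave open whether a piperazine or a carboxylic acid on a longer chain, placed on this carbonyl carbon, would give a step beyond the scatter.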